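The source may report more compounds than this note shows. Statements on the series, on what has been measured and on what is new or still open speak of the compounds shown alone.

Measured compounds in a functional assay on the whole organism (strain Wistar) for inhibition, with Rattus norvegicus as the target, read by paw edema, with stated times of 30 min and 3 h, at a dose of 200 mg/kg by the oral route; a lower number here means less inhibition, a higher number more inhibition at the dose given (going by the name of the read-out):
compound 1, `O=C(O)c1cc(-n2c(-c3ccccc3)cc3c2CCCC3)ccc1O`: >= 60%
compound 2, `O=C(O)c1cc(-n2c(-c3ccccc3)cc3c2CCCC3)c(C(F)(F)F)cc1O`: 0%
compound 3, `CC(=O)Nc1cc(-n2c(-c3ccccc3)cc3c2CCCC3)cc(C(=O)O)c1O`: 0%

The value of compound 1 is a limit of this assay and not a number, as the limit of >= 60% in this assay, at which 1 of the 3 values shown sits, shows. Compound 2 and compound 3 each altered an aromatic carbon of the shared core, and both steps were large: a number at least 60 percentage points lower from compound 1 to compound 2 (beyond the scatter) and a number at least 60 percentage points lower from compound 1 to compound 3 (beyond the scatter). Compound 4, `O=C(O)c1cc(-n2c(-c3cccc(C(F)(F)F)c3)cc3c2CCCC3)ccc1O`, is not yet measured; it differs from compound 1 in this way: trifluoromethyl in place of hydrogen on an aromatic carbon. The changed aromatic carbon is a different one from those of compound 2 and compound 3, so the measured steps bear on it only loosely. A moderate fall in this assay is expected for compound 4, a number at least 20 percentage points lower from compound 1 to compound 4 (beyond the scatter), though a change within the scatter cannot be excluded. Compound 4 is estimated at 40%, ranging from 10% to 70%.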

Compound 4, a percentage reported as inhibition, in the whole organism at one dose (the size of the read-out at that dose, not a potency): 20%
Beside the measured number, compound 4's estimate is 20 percentage points above it, within the range that was stated.
By their numbers in this assay, from the lowest: compounds 2 and 3 (each within the scatter of the next); then compound 4. At a limit, above all of these: compound 1.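

Trifluoromethyl in place of hydrogen on an aromatic carbon of a six-membered aromatic ring of carbon only, meta to a large group, gives a number at least 40 percentage points lower from compound 1 to compound 4 (beyond the scatter) in this assay. The loss of inhibition is therefore not confined to the carbons changed in compound 2 and compound 3, although compound 4 still shows 20%. The reading for compound 1 is a limit and not a number: the limit of >= 60% in this assay, at which 1 of the 4 values shown sits.

On these data alone, whether a methyl group, a chlorine atom or an amine on this carbon would lower the inhibition as well stays open. So does the effect of trifluoromethyl on the other carbons of this ring.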